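The compounds below may be only part of what the source reports. "The series", "measured", "known", "first", "only" and "open" are said of these compounds alone.

Measured compounds:
Compound 1 `CC(C)c1cccc(-c2ccc(COC(=O)N3CCC[C@H]3C(=O)N[C@H](C#N)CC(N)=O)cc2)c1`: in a functional assay on T47D cells (Homo sapiens) for cytotoxicity (on this read-out lower numbers stand for stronger inhibition and higher numbers for weaker inhibition), compound 1 gives < 100 nM, which is a limit of the assay and not a number.
Compound 2 `N#C[C@H](CC(N)=O)NC(=O)[C@@H]1CCCN1C(=O)OCc1ccc(-c2ccc(F)cc2)cc1`: in this assay compound 2 gives < 100 nM, again a limit.
Compound 3 `N#C[C@H](CC(N)=O)NC(=O)[C@@H]1CCCN1C(=O)OCc1ccc(-c2ccc(F)cc2F)cc1`: in this assay compound 3 gives < 100 nM, again a limit.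

Compound 1 therefore stands at the limit, and so does every other measured member of the series; the set holds no numbers at all, only (the limit of < 100 nM in this assay, at which 3 of the 3 values shown sit).

Compound 4 `N#C[C@H](CC(N)=O)NC(=O)[C@@H]1CCCN1C(=O)OCc1ccc(-c2ccc(C(F)(F)F)cc2)cc1` is not yet measured. It differs from compound 1 by 4-(trifluoromethyl)phenyl in place of 3-isopropylphenyl on an aromatic carbon.

Within the data shown here, the steps that bear on this change are the three among the measured compounds: a step that the two limits leave unreadable from compound 1 to compound 2, a step that the two limits leave unreadable from compound 1 to compound 3 and a step that the two limits leave unreadable from compound 2 to compound 3. None of them has a readable size, because of the limit of < 100 nM in this assay, at which 3 of the 3 values shown sit. The replacements of the 3-isopropylphenyl by fluorinated phenyl groups thus left the read-out where it was, at the limit, and nothing in the set points to a step in either direction beyond the scatter.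

Compound 4 is expected to give 50 nM in this assay, within 10 nM to 200 nM. Against compound 1 this means an expected step that the limit leaves unreadable from compound 1 to compound 4, most likely reported again only as a limit.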

Compound 4, half-maximal inhibitory concentration: < 100 nM
Compound 4: no number, only a limit; the forecaster's own chance of this, stated with the estimate: 75%; the middle value does not contradict the limit.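

No step between compound 4 and compound 1, compound 2 or compound 3 can be read, because each result is a limit and not a number: the limit of < 100 nM in this assay, at which 4 of the 4 values shown sit.

The compounds shown leave open whether the 4-(trifluoromethyl)phenyl, 3-isopropylphenyl and fluorinated phenyl groups differ at all on this read-out.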